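Adding a Methoxy to the Dimethoxyphenyl of Compound 2

The compounds below may be only part of what the source reports. "The series", "measured", "known", "first", "only" and "open" are said of these compounds alone.

Of the compounds shown here, two sharing one core have been tested. Compound 1 `COc1cc(Cn2cc(CNC(=O)c3cn(-c4ccccc4)nc3-c3ccc(F)cc3)nn2)cc(OC)c1OC` gives 4300 nM in a functional assay on MCF7 cells (Homo sapiens) for antiproliferative activity, read by sulforhodamine B assay, with a stated time of 48 h; a lower number here means a stronger inhibitor of growth, a higher number a weaker inhibitor of growth. Compound 2 `COc1cc(Cn2cc(CNC(=O)c3cn(-c4ccccc4)nc3-c3ccc(Cl)cc3)nn2)cc(OC)c1` gives 150 nM in this assay, the lower of the two numbers, with compound 1 standing well apart from it. The two differ in more than one place, so their gap cannot be tied to a single change.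

Compound 3 `COc1cc(Cn2cc(CNC(=O)c3cn(-c4ccccc4)nc3-c3ccc(Cl)cc3)nn2)cc(OC)c1OC` carries the change (methoxy in place of hydrogen on an aromatic carbon), ortho to two methoxy groups and para to a large group. Among the compounds with values here, no measured pair shows this step alone. Because compound 1, which also bears the trimethoxyphenyl, gives 4300 nM, the step is expected to weaken growth inhibition, though its size is uncertain, and the expected step of a 5.3-fold higher number from compound 2 to compound 3 (0.73 log units; beyond the scatter) is taken as moderate. Compound 3 is therefore expected to give about 800 nM, within 150 nM to 5000 nM.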

Compound 3, concentration for 50% growth inhibition: 2500 nM
Beside the measured number, compound 3's estimate is 3.1-fold (0.49 log units) below it; low and high end bracket the measured number.
By their numbers in this assay, from the lowest: compound 2; then compounds 3 and 1 (each within the scatter of the next).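

In this assay, the change from 3,5-dimethoxyphenyl to 3,4,5-trimethoxyphenyl now has a measured size of its own: a 17-fold higher number from compound 2 to compound 3 (1.22 log units; beyond the scatter). A methoxy on this aromatic carbon, ortho to two methoxy groups and para to a large group, therefore costs much of the growth inhibition seen without it. With the 3,4,5-trimethoxyphenyl in place, chloro in place of fluoro gives a 1.7-fold lower number from compound 1 to compound 3 (0.24 log units; within the scatter), so no difference can be read from that exchange, and nothing available explains either result.

As far as these compounds go, it remains open whether a hydroxy group or an amine on this same carbon would bring a similar loss. Also open, from the compounds shown here alone, is whether fluoro and chloro would stay indistinguishable on the 3,5-dimethoxyphenyl series.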